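A few compounds are considered here, and "the series" means these few. Any claim that something is new, unique, unknown or untested is made for them only; others in the source may bear on it.

Working notes on the series, read in an ADME assay on MT4 cells (Homo sapiens) for cytotoxicity, read by MTT assay; on this read-out lower numbers stand for higher toxicity in this test and higher numbers for lower toxicity in this test. Compound 1 (`O=C1c2ccccc2C(=O)N1CCOC(=S)N(C(=O)c1ccc([N+](=O)[O-])cc1)c1ccc(Cl)cc1`) gives > 100000 nM, which is a limit. For the measured compounds named here, compound 2 (`O=C1c2ccccc2C(=O)N1CCOC(=S)N(C(=O)c1c(F)cccc1F)c1ccc(Cl)cc1`) gives 39000 nM, the only number so far. Compound 3 (`O=C1c2ccccc2C(=O)N1CCOC(=S)N(C(=O)c1cc(Cl)cc(Cl)c1)c1ccc(Cl)cc1`) carries 3,5-dichlorophenyl in place of 2,6-difluorophenyl on a carbonyl carbon. Going by the values given here, the one measured step at this place, an at least 2.5-fold lower number from compound 1 to compound 2 (0.40 log units; beyond the scatter), is modest and has an open end (the limit of > 100000 nM in this assay, at which 1 of the 2 values shown sits), so it sets a scale but gives no direction. The expected step is a 1.2-fold higher number from compound 2 to compound 3 (0.06 log units; within the scatter), with no move beyond the scatter expected in this assay. The estimate for compound 3 is 45000 nM, with an expected range of 15000 nM to 100000 nM.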

Compound 3, half-maximal cytotoxic concentration: 32000 nM
For compound 3 the middle estimate is 1.4-fold (0.15 log units) above the measured one; measured number inside the range.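

In this assay, the change at this carbonyl carbon from 2,6-difluorophenyl to 3,5-dichlorophenyl gives a 1.2-fold lower number from compound 2 to compound 3 (0.09 log units; within the scatter), so these two groups cannot be told apart here. Against the 4-nitrophenyl of compound 1, the second group gives an at least 3.1-fold lower number from compound 1 to compound 3 (0.49 log units; beyond the scatter), which now makes two steps from that compound with the same sign. The size of both steps stays open-ended: the limit of > 100000 nM in this assay, at which 1 of the 3 values shown sits.

The compounds shown leave open how a longer chain in place of the aromatic ring would read. Going by these compounds, a phenyl carrying an amine or a carboxylic acid is equally open.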